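Chloro to Fluoro Exchange on the Shared Core

The source may report more compounds than this note shows. Statements on the series, on what has been measured and on what is new or still open speak of the compounds shown alone.

Of the compounds shown here, three built on one shared core have been measured in an in vitro functional assay on HEK293-A cells for positive allosteric modulation of metabotropic glutamate receptor 5 (Homo sapiens), read by FLIPR and calcium flux; a higher number here means that more compound is needed for the effect, a lower number that less compound is needed. Compound 1 `O=C1CC(c2nc(-c3cccc(F)c3)no2)CN1c1ccc(Cl)cc1` gives 630 nM. Compound 2 `O=C1CC(c2nc(-c3ccc(F)cc3)no2)CN1c1ccc(Cl)cc1` gives 1700 nM, and compound 3 `O=C1CC(c2nc(-c3cccc(Cl)c3)no2)CN1c1ccc(Cl)cc1` gives 140 nM. Compound 1 thus stands second highest of the three numbers: the step of a 2.7-fold higher number from compound 1 to compound 2 (0.43 log units; beyond the scatter) is modest, the step of a 4.5-fold lower number from compound 1 to compound 3 (0.65 log units; beyond the scatter) is modest in the other direction, and the step of a 12-fold lower number from compound 2 to compound 3 (1.08 log units; beyond the scatter) is large.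

Compound 4 `O=C1CC(c2nc(-c3cccc(F)c3)no2)CN1c1ccc(F)cc1` has not yet been measured. It differs from compound 1 in one place: fluoro in place of chloro on an aromatic carbon. Of the measured steps, only a 4.5-fold lower number from compound 1 to compound 3 (0.65 log units; beyond the scatter) involves an exchange between chloro and fluoro, and there the exchange ran from fluoro to chloro on a different aromatic ring. For the measured compounds named here, the reverse exchange here, on the ring para to a large group, might be expected to push the number upward, though no measured compound bears directly on this ring. The step of a 1.9-fold higher number from compound 1 to compound 4 (0.28 log units; within the scatter) is therefore expected to be modest, toward a higher number. Compound 4 is estimated at 1200 nM, within a range from 400 nM to 3500 nM.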

Compound 4, half-maximal effective concentration: 88 nM
Compound 4: middle estimate off by 14-fold (1.13 log units), on the high side; the measured number lies below the stated range.
By their numbers in this assay, from the lowest: compounds 4 and 3 (each within the scatter of the next); then compound 1; then compound 2.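

Compounds 1, 2 and 3 all carry the 4-chlorophenyl group, so they could say nothing about this position; the change from 4-chlorophenyl to 4-fluorophenyl now shows that it matters in this assay, with a 7.2-fold lower number from compound 1 to compound 4 (0.85 log units; beyond the scatter). The earlier exchange on the other aromatic ring ran the opposite way, fluoro to chloro, and also lowered the number, with a 4.5-fold lower number from compound 1 to compound 3 (0.65 log units; beyond the scatter), so among these compounds no single preference between the two halogens holds across both rings. Nothing given here explains why fluoro lowers the number at this position.

Still open, from the compounds shown here alone, is whether the same exchange would lower the number with the 3-chlorophenyl group of compound 3 or the 4-fluorophenyl group of compound 2 in place. The compounds shown also do not tell how a methoxy group, a methyl group or a plain hydrogen would behave at this place.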